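Extending the alkoxy chain of compound 3 with a sulfur

The source may hold more compounds than are shown below. What is called first, only, known or untested is meant among the compounds shown, and "the series" means these compounds.

The compounds share the core of compound 1 `Nc1ccc2cccc(OC3CCCCC3)c2n1` and differ only in the group on the oxygen on the aromatic ring. In an assay on cells with melanin-concentrating hormone receptor 1 (Homo sapiens) as the target, read by radioligand binding (a lower number here means a stronger inhibitor, a higher number a weaker inhibitor), compound 1 gives 361 nM. Compound 2 `CCCCCOc1cccc2ccc(N)nc12` carries a pentyl there, and in this assay compound 2 gives 580 nM. Compound 3 `CCCOc1cccc2ccc(N)nc12` carries a propyl, and in this assay compound 3 gives 1100 nM, the highest of the three numbers; the step of a 3.0-fold higher number from compound 1 to compound 3 (0.48 log units; beyond the scatter) lies beyond the scatter, while the step of a 1.9-fold higher number from compound 2 to compound 3 (0.28 log units; within the scatter) does not.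

Compound 4 `CSCCOc1cccc2ccc(N)nc12` is made from compound 3 by the change (methylsulfanyl in place of methyl on a saturated chain carbon, two bonds along the chain from an oxygen on an aromatic ring). Of the measured steps, the one that bears on it is a 1.9-fold higher number from compound 2 to compound 3 (0.28 log units; within the scatter), where a longer chain on the same oxygen went with a somewhat lower number, but one inside the scatter. The chain of compound 4 is longer than that of compound 3 by the sulfur, so the step of a 1.6-fold lower number from compound 3 to compound 4 (0.20 log units; within the scatter) is expected to be small, towards a lower number, and likely within the scatter. Compound 4 is therefore estimated to give 700 nM in this assay, within a range of 300 nM to 1600 nM.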

Compound 4, half-maximal inhibitory concentration: > 2000 nM
Compound 4 ended at the assay's limit; the forecaster's own chance of this, stated with the estimate: 3%; middle value at least 2.8-fold (0.45 log units) away from the limit.
By their numbers in this assay, from the lowest: compounds 1, 2 and 3 (each within the scatter of the next, the first and the last beyond it). At a limit, above all of these: compound 4.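

In this assay compound 4 is recorded only as a limit of the assay and not as a number: the limit of > 2000 nM in this assay, at which 1 of the 4 values shown sits. Against the two larger groups on this oxygen the change counts clearly, with an at least 3.4-fold higher number from compound 2 to compound 4 (0.53 log units; beyond the scatter) and an at least 5.5-fold higher number from compound 1 to compound 4 (0.74 log units; beyond the scatter), so 2-(methylsulfanyl)ethyl does not fall in line with pentyl or cyclohexyl, and the length of the chain alone does not set the number at this position. Against propyl the reading is weaker, since an at least 1.8-fold higher number from compound 3 to compound 4 (0.25 log units; that floor lies within the scatter) gives only a floor; even so, the lengthened chain of compound 4 goes against the earlier link between a larger group and a lower number, which compounds 1 to 3 had suggested.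

Going by these compounds, how far compound 4 lies past its limit stays open, so the true size of all three steps is unknown. The compounds shown also leave open whether the sulfur itself carries the change: a butyl chain or a 2-methoxyethyl group, with oxygen in the place of sulfur, would separate the effect of that atom from the effect of the chain.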